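A Nitrogen-Linked Aryl Replaces the Group of Compound 2

This account rests on a few compounds, and the source may have more. Where it says the series, first, only, none or still open, it means among the compounds named here.

In a functional assay on HeLa cells (Homo sapiens) for antiproliferative activity, read by MTT assay, with a stated time of 72 h (a lower number here means a stronger inhibitor, a higher number a weaker inhibitor), compound 1 (`COc1cc(C(=O)c2sc3ccccc3c2-c2ccccc2)cc(OC)c1OC`) gives 1900 nM, and compound 2 (`COc1ccc(-c2c(C(=O)c3cc(OC)c(OC)c(OC)c3)sc3ccccc23)cc1C`) gives 10000 nM, the higher of the two numbers and so the weaker result. The next compound, compound 3 (`COc1cc(C(=O)c2sc3ccccc3c2Nc2ccc(C)cc2)cc(OC)c1OC`), has not yet been measured. It carries (4-methylphenyl)amino in place of 4-methoxy-3-methylphenyl on an aromatic carbon. Within the data shown here, only one measured step bears on this change, a 5.3-fold higher number from compound 1 to compound 2 (0.72 log units; beyond the scatter), and it brought in the very group that now leaves. Among the measured compounds shown here, that single step is modest but beyond the scatter, and no measured compound yet carries the amino link, so the evidence is thin. A move back toward compound 1 of similar or smaller size is expected in this assay. The expected step is a 3.3-fold lower number from compound 2 to compound 3 (0.52 log units; beyond the scatter). For compound 3 the estimate is 3000 nM, within a range of 500 nM to 10000 nM.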

Compound 3, half-maximal inhibitory concentration: 3500 nM
Compound 3: middle estimate off by 1.2-fold (0.07 log units), on the low side, within the range that was stated.
By their numbers in this assay, from the lowest: compounds 1 and 3 (each within the scatter of the next); then compound 2.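

In this assay, the position on the aromatic carbon of the five-membered ring accepts an aryl group joined through an amino nitrogen: replacing 4-methoxy-3-methylphenyl with (4-methylphenyl)amino gives a 2.9-fold lower number from compound 2 to compound 3 (0.46 log units; beyond the scatter). Set against the plain phenyl group, the same amino-linked aryl gives a 1.8-fold higher number from compound 1 to compound 3 (0.27 log units; within the scatter), so compound 1 and compound 3 cannot be told apart here, and a substituted aryl at this position need not cost what compound 2 suggested. Nothing in the data explains these numbers at the level of mechanism.

Compound 3 differs from compound 2 in both the link and the ring substituents, so the share of each in the step remains unresolved. A plain phenylamino group, or a 4-methoxyphenylamino group, would bear on that question, and a saturated amine such as morpholine would test whether the aryl ring matters here at all.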